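The source may hold more compounds than are shown below. What is called first, only, known or untested is meant among the compounds shown, and "the series" means these compounds.

Measured so far in an assay on Sf9 cells for inhibition of serine/threonine-protein kinase 4 (Homo sapiens), read by luminescence and ADP-Glo, with a stated time of 1 h, in the presence of a further agent that is not named here; on this read-out higher numbers stand for weaker inhibition and lower numbers for stronger inhibition:
compound 1 `CN1C(=O)C(CC2CC2)N(C)c2nc(Nc3ccc(S(N)(=O)=O)cc3)ncc21` gives 211 nM
compound 2 `CN1C(=O)C(c2ccccc2)N(C)c2nc(Nc3ccc(S(N)(=O)=O)cc3)ncc21` gives 383 nM
compound 3 `Cc1ccc(F)cc1C1C(=O)N(C)c2cnc(Nc3ccc(S(N)(=O)=O)cc3)nc2N1C` gives 168 nM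

Compound 3 shows the lowest of the three numbers, but only a 2.3-fold lower number from compound 2 to compound 3 (0.36 log units; beyond the scatter) lies beyond the scatter, while a 1.3-fold lower number from compound 1 to compound 3 (0.10 log units; within the scatter) does not. Compound 4 `CN1C(=O)C(Cc2ccccc2)N(C)c2nc(Nc3ccc(S(N)(=O)=O)cc3)ncc21` differs from compound 3 by benzyl in place of 5-fluoro-2-methylphenyl on a saturated ring carbon. The swaps already seen at this carbon, a 1.8-fold higher number from compound 1 to compound 2 (0.26 log units; within the scatter) and a 2.3-fold lower number from compound 2 to compound 3 (0.36 log units; beyond the scatter), were modest, and benzyl resembles both the phenyl of compound 2 and the cyclopropylmethyl of compound 1. Compound 4 is therefore expected to give a number close to those, that is a 1.5-fold higher number from compound 3 to compound 4 (0.19 log units; within the scatter). The estimate for compound 4 is 260 nM, with a range from 110 nM to 620 nM.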

Compound 4, half-maximal inhibitory concentration: > 10000 nM
Compound 4 was reported as a limit; the forecaster's own chance of this, stated with the estimate: 2%; at least 38-fold (1.58 log units) between middle value and limit.
By their numbers in this assay, from the lowest: compounds 3, 1 and 2 (each within the scatter of the next, the first and the last beyond it). At a limit, above all of these: compound 4.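

Compound 4 stands at a limit of the assay, not at a measured number: the limit of > 10000 nM in this assay, at which 1 of the 4 values shown sits. Even so, benzyl on this saturated ring carbon gives far larger steps than any earlier swap there: an at least 59-fold higher number from compound 3 to compound 4 (1.77 log units; beyond the scatter), an at least 26-fold higher number from compound 2 to compound 4 (1.41 log units; beyond the scatter) and an at least 47-fold higher number from compound 1 to compound 4 (1.67 log units; beyond the scatter). Groups that look alike can therefore part sharply at this position, since phenyl and cyclopropylmethyl stayed close to 5-fluoro-2-methylphenyl.

The compounds shown do not tell why benzyl differs. They also leave open whether a longer chain ending in phenyl, or a benzyl carrying an amine, would behave the same way.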